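The compounds below may be only part of what the source reports. "The series", "measured", "known", "first", "only" and "open" are said of these compounds alone.

Measured so far in a functional assay (trachea) with Cavia porcellus as the target; on this read-out lower numbers stand for stronger inhibition and higher numbers for weaker inhibition:
compound 1 `CC(C)n1nc(-c2cccnc2)c2ccccc2c1=O`: 3090 nM
compound 2 `CCCCCCCCn1nc(-c2cccnc2)c2ccccc2c1=O`: 21900 nM
compound 3 `CC(C)=CCn1nc(-c2cccnc2)c2ccccc2c1=O`: 1380 nM

Compound 1, which carries an isopropyl group, sits in the middle of these three numbers, with compound 3 lower and compound 2 higher. The unmeasured compound 4 `O=c1c2ccccc2c(-c2cccnc2)nn1Cc1ccccc1` keeps the core of compound 1 and differs in one place, with benzyl in place of isopropyl on an aromatic nitrogen.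

Among the compounds with values here, no measured compound has a ring at this place, so the evidence is indirect. Two measured steps replace the same isopropyl group. The first, a 2.2-fold lower number from compound 1 to compound 3 (0.35 log units; beyond the scatter), introduces 3-methylbut-2-en-1-yl and is modest. The second, a 7.1-fold higher number from compound 1 to compound 2 (0.85 log units; beyond the scatter), introduces octyl, is also modest and runs the opposite way. The difference between those two products, a 16-fold lower number from compound 2 to compound 3 (1.20 log units; beyond the scatter), is large, so the choice of group at this place clearly matters.

Benzyl looks more like the short unsaturated group of compound 3 at 1380 nM than the long chain of compound 2 at 21900 nM, so a slightly lower number is expected. The expected change is a 1.7-fold lower number from compound 1 to compound 4 (0.23 log units; within the scatter), which may not clear the usual scatter. For compound 4 the estimated value is 1800 nM, with an expected range from 600 nM to 6000 nM.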

Compound 4, half-maximal inhibitory concentration: 2450 nM
For compound 4 the middle estimate is 1.4-fold (0.13 log units) below the measured one; measured number inside the range.
By their numbers in this assay, from the lowest: compounds 3, 4 and 1 (each within the scatter of the next, the first and the last beyond it); then compound 2.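

In this assay the ring of benzyl is accepted at this place on the aromatic nitrogen about as well as the smaller groups: benzyl in place of isopropyl gives a 1.3-fold lower number from compound 1 to compound 4 (0.10 log units; within the scatter) and phenyl in place of 2-methylprop-1-en-1-yl gives a 1.8-fold higher number from compound 3 to compound 4 (0.25 log units; within the scatter) so compound 4 cannot be told apart from compound 1 or compound 3, even though those two are separated from each other. The octyl chain alone stands clearly apart from benzyl, with phenyl in place of heptyl giving an 8.9-fold lower number from compound 2 to compound 4 (0.95 log units; beyond the scatter) and this shows that a large group at this place need not bring the weaker inhibition seen with compound 2. No measurement shown here explains why these groups give these numbers.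

Still open, as far as these compounds go, is whether a chloro or methoxy group on the benzyl ring would shift the number, and whether a longer link, as in 2-phenylethyl, would behave like benzyl or like octyl. From the compounds shown here alone, the effect of an amine or a carboxylic acid at the end of a chain at this place also remains unknown.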